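Formyl for pentyl on the shared core and its expected effect

This account rests on a few compounds, and the source may have more. Where it says the series, first, only, none or still open, it means among the compounds named here.

Measured compounds:
compound 1 `CCCc1cc(C(C)=O)c(O)cc1OCCCCC#N`, 84%
compound 2 `CCCCCc1cc(C(C)=O)c(O)cc1OCCCCC#N`, 31%
compound 3 `CC(=O)c1cc(CO)c(OCCCCCCC#N)cc1O`, 40%

In an assay on isolated protein for inhibition of leukotriene B4 receptor 1 (Homo sapiens), tested at 10 uM (on this read-out higher numbers stand for more inhibition at the one concentration tested (going by the name of the read-out) and lower numbers for less inhibition), compound 1 gives 84%, compound 2 gives 31% and compound 3 gives 40%. Compound 2 stands lowest of the three numbers; compound 3 sits only a little higher, within the scatter, while compound 1 is far higher, beyond the scatter. For the measured compounds named here, the one measured step, a number 53 percentage points lower from compound 1 to compound 2 (beyond the scatter), shows that growing the saturated chain by ethyl in place of hydrogen, three bonds along the chain from an aromatic carbon, cost much in this assay.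

Compound 4 `CC(=O)c1cc(C=O)c(OCCCCC#N)cc1O` has not yet been measured. It differs from compound 2 by formyl in place of pentyl on an aromatic carbon. Going by the values given here, no measured step removes the whole pentyl or brings in a formyl, so the step from compound 1 to compound 2 bears on it only loosely: it says that a longer saturated chain at this position hurts, and compound 4 has no such chain at all. Compound 3, which carries a hydroxymethyl at the same place with a longer cyanoalkoxy group, gives a number close to that of compound 2, which argues against a large recovery.

The step from compound 2 to compound 4 is therefore expected to be a modest rise, a number 14 percentage points higher from compound 2 to compound 4 (beyond the scatter), possibly within the scatter. Compound 4 is estimated at 45%, with a range from 25% to 70%.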

Compound 4, a percentage reported as inhibition, at one concentration (the size of the read-out at that concentration, not a potency): 6%
Beside the measured number, compound 4's estimate is 39 percentage points above it; the whole stated range lies above it.
By their numbers in this assay, from the lowest: compound 4; then compounds 2 and 3 (each within the scatter of the next); then compound 1.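

In this assay, putting formyl on the aromatic carbon ortho to a 4-cyanobutoxy group gives a number 25 percentage points lower from compound 2 to compound 4 (beyond the scatter), and against the propyl compound it gives a number 78 percentage points lower from compound 1 to compound 4 (beyond the scatter). The earlier pair showed only that pentyl stands well under propyl at this place, whereas the new compound shows that a group with fewer heavy atoms than pentyl does not by that alone recover the number: the order is propyl highest, pentyl lower and formyl lowest, with every gap beyond the scatter, so the numbers do not follow the size of the group. The compounds shown offer no measurement that would account for this drop.

On these data alone, whether a butyl or an ethyl group on the same carbon would stand nearer to compound 1 or to compound 2 stays open, and with it how narrowly the high number is tied to propyl. As far as these compounds go, it is also open whether a carboxylic acid or an aminomethyl group at this place would stand as low as compound 4, or whether that low number belongs to formyl alone.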